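The compounds below may be only part of what the source reports. "The series", "measured", "known", "first", "only" and "open" are said of these compounds alone.

Compound 1 `O=CNC[C@H]1CN(c2ccc(-n3cc(-c4ccccn4)cn3)c(F)c2)C(=O)O1` and compound 2 `O=C(NC[C@H]1CN(c2ccc(-n3cc(-c4ccccn4)cn3)c(F)c2)C(=O)O1)C(F)F` share one core and differ only in the group on the carbonyl carbon, where compound 2 carries difluoromethyl in place of hydrogen. Both were tested in an ADME assay on L02 cells (Homo sapiens) for cytotoxicity, read by MTT assay, with a stated time of 48 h; a lower number here means a stronger inhibitor, a higher number a weaker inhibitor. In this setting compound 1 gives > 400 ug/mL, which is a limit of the assay rather than a number. Compound 2 gives > 400 ug/mL, again a limit of the assay. The step that the two limits leave unreadable from compound 1 to compound 2 cannot be read, since the limit of > 400 ug/mL in this assay, at which 2 of the 2 values shown sit, marks where both values sit. Compound 3 `NC(=O)[C@H]1CN(c2ccc(-n3cc(-c4ccccn4)cn3)c(F)c2)C(=O)O1` is not yet measured. Its change from compound 2 is carbamoyl in place of (((difluoromethyl)carbonyl)amino)methyl on a saturated ring carbon. Among the compounds with values here, no measured step bears on this change, and the only two values known are both limits. The expectation for compound 3 is therefore that it stays at that limit as well, so that the step of a number no higher from compound 2 to compound 3 (the limit leaves the size open) is estimated to be none beyond the scatter. Compound 3 is estimated at 400 ug/mL, with an expected range from 200 ug/mL to 800 ug/mL.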

Compound 3, half-maximal inhibitory concentration: 119 ug/mL
Compound 3: the middle estimate sits 3.4-fold (0.53 log units) above what was measured, outside the stated range (below it).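

Until now the group on this saturated ring carbon, next to the ring oxygen, had given no readable change, since altering the far end of the side chain left both compounds at a limit of the assay. In this assay the result is different: putting carbamoyl on this carbon gives an at least 3.3-fold lower number from compound 2 to compound 3 (0.52 log units; beyond the scatter) and gives an at least 3.3-fold lower number from compound 1 to compound 3 (0.52 log units; beyond the scatter) as well, so the read-out does respond to what sits at this position, and a real number comes within reach of the assay. As far as these compounds go, each of these two steps is a minimum rather than a full size, and the true gap stays unknown, because one end of each step is a limit: the limit of > 400 ug/mL in this assay, at which 2 of the 3 values shown sit.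

The swap removes the whole (((difluoromethyl)carbonyl)amino)methyl chain at once, so the compounds shown cannot tell whether the carbamoyl group itself or the loss of the longer chain lowers the number. A carboxylic acid, a methyl ester or an aminomethyl group on the same ring carbon would be needed to separate these two readings.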